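Swapping a side chain on a shared core

The compounds below may be only part of what the source reports. "The series", "measured", "known", "first", "only" and "open" are said of these compounds alone.

Measured in an ADME assay on microsomes from liver (Rattus norvegicus) for metabolic stability, using NADPH, with a stated time of 10 min (a lower number here means that less of the compound is left, a higher number that more of the compound is left), so far:
compound 1 `NCCCCN(C[C@@H]1Cc2ncccc2CN1)[C@H]1CCCc2cccnc21` with 55% left
compound 2 `CN(C[C@@H]1Cc2ncccc2CN1)[C@H]1CCCc2cccnc21` with 1% left
compound 3 `NC/C=C/CN(C[C@H]1Cc2ncccc2CN1)[C@H]1CCCc2cccnc21` with 11% left

Compound 3 at 11% left lies within the usual scatter of compound 2 at 1% left, whereas the gap to compound 1 at 55% left lies beyond the scatter. Compound 4 `CN(C)CCCCN(C[C@H]1Cc2ncccc2CN1)[C@H]1CCCc2cccnc21` differs from compound 3 by 3-(dimethylamino)propyl in place of 3-aminoprop-1-en-1-yl on a saturated chain carbon bound to an amine nitrogen with 3-(dimethylamino)propyl in place of 3-aminoprop-1-en-1-yl on a saturated chain carbon bound to an amine nitrogen. For the measured compounds named here, one measured step bears on this, a number 54 percentage points lower from compound 1 to compound 2 (beyond the scatter) with hydrogen in place of 3-aminopropyl. That step removes a chain outright, so it shows only that this place can matter. Going by the values given here, no measured compound carries 3-(dimethylamino)propyl, so only a small rise is expected, with the estimated change a number 9 percentage points higher from compound 3 to compound 4 (within the scatter) and no clear move beyond the scatter. For this assay the estimated value of compound 4 is 20% with an expected range from 4% to 50% around it.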

Compound 4, percent of the compound remaining: 27%
Beside the measured number, compound 4's estimate is 7 percentage points below it; low and high end bracket the measured number.
By their numbers in this assay, from the lowest: compounds 2 and 3 (each within the scatter of the next); then compound 4; then compound 1.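

The earlier compounds shown here showed only that removing a chain at this place can matter, whereas in this assay there is a number 16 percentage points higher from compound 3 to compound 4 (beyond the scatter), showing that exchanging one chain for another can also shift the number. This single change lengthens the chain, removes the double bond and removes the hydrogen-bond donor, and the step alone does not separate these differences. No measurement here explains the rise. Which of these differences carries the step stays open, as does the outcome for a longer chain or a chain carrying a carboxylic acid at this place.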